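Aryl swap on the shared core: thiophen-2-yl to pyridin-3-yl

A few compounds are considered here, and "the series" means these few. Any claim that something is new, unique, unknown or untested is made for them only; others in the source may bear on it.

- compound 1 `COC(=O)C1=C(C)NC(C)=C(C(=O)OC)C1c1c(-c2cccnc2)nc2sc(C)cn12`: 16000 nM
- compound 2 `COC(=O)C1=C(C)NC(C)=C(C(=O)OC)C1c1c(-c2ccccn2)nc2sccn12`: 2570 nM
- compound 3 `COC(=O)C1=C(C)NC(C)=C(C(=O)OC)C1c1c(-c2cccs2)nc2sccn12`: 110 nM

In a functional assay on ileum (Cavia porcellus) for inhibition (on this read-out higher numbers stand for weaker inhibition and lower numbers for stronger inhibition), compound 3 gives the lowest number of the three, 110 nM. The next structure, compound 4 `COC(=O)C1=C(C)NC(C)=C(C(=O)OC)C1c1c(-c2cccnc2)nc2sccn12`, carries pyridin-3-yl in place of thiophen-2-yl on an aromatic carbon. The closest measured step is a 23-fold lower number from compound 2 to compound 3 (1.37 log units; beyond the scatter), with thiophen-2-yl in place of pyridin-2-yl. Leaving thiophen-2-yl for a pyridine is thus expected to run the opposite way, with a large rise of similar size in this assay. Compound 1 also carries pyridin-3-yl and gives 16000 nM, which points the same way. The estimate is a step of a 23-fold higher number from compound 3 to compound 4 (1.36 log units; beyond the scatter). Compound 4 is expected at 2500 nM, with an estimated range of 500 nM to 12000 nM.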

Compound 4, half-maximal inhibitory concentration: 3550 nM
Compound 4: middle estimate off by 1.4-fold (0.15 log units), on the low side; the range from low to high includes it.
By their numbers in this assay, from the lowest: compound 3; then compounds 2 and 4 (each within the scatter of the next); then compound 1.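

Reading this assay, the drop on leaving thiophen-2-yl holds for pyridin-3-yl as well as pyridin-2-yl, with a 32-fold higher number from compound 3 to compound 4 (1.51 log units; beyond the scatter). The two pyridines are not separated, with a 1.4-fold higher number from compound 2 to compound 4 (0.14 log units; within the scatter), so among these three aryl groups only thiophen-2-yl stands apart at this place. The methyl of compound 1 can now be read alone: hydrogen in its place gives a 4.5-fold lower number from compound 1 to compound 4 (0.65 log units; beyond the scatter).

No evidence at hand explains the gap between thiophen-2-yl and the pyridines. Open, going by these compounds, is whether phenyl or furan-2-yl here would track thiophen-2-yl or the pyridines, and whether the methyl step carries over to thiophen-2-yl.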